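From Cyclopropylcarbonyl to Ethylcarbamoyl in an Inactive Series

A few compounds are considered here, and "the series" means these few. Any claim that something is new, unique, unknown or untested is made for them only; others in the source may bear on it.

Three measured compounds share a core, and every one of them sits at the limit of an assay on Sf9 cells for inhibition of inhibitor of nuclear factor kappa-B kinase subunit epsilon (Homo sapiens), read by ADP-Glo, with a stated time of 60 min; a lower number here means a stronger inhibitor, a higher number a weaker inhibitor. Compound 1, `Cc1[nH]nc(N)c1-c1cccc(OC(F)(F)F)c1`, gives > 100000 nM, which is a limit of the assay rather than a number. Compound 2, `Cc1nn(C(=O)C2CC2)c(N)c1-c1ccc(Cl)c(Cl)c1`, gives > 100000 nM, again a limit and not a measured value. Compound 3, `Cc1nn(C(=O)C2CC2)c(N)c1-c1ccc(Cl)cc1`, gives > 100000 nM, also a limit. Among the compounds with values here, the step that the two limits leave unreadable from compound 2 to compound 3 therefore cannot be read in either direction, and the only evidence available is the limit of > 100000 nM in this assay, at which 3 of the 3 values shown sit.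

Compound 4, `CCNC(=O)n1nc(C)c(-c2ccc(Cl)c(Cl)c2)c1N`, differs from compound 2 in one place: ethylamino in place of cyclopropyl on a carbonyl carbon. Within the data shown here, no measured step touches the carbonyl carbon; the single measured step, from compound 2 to compound 3, alters a chloro on the aromatic ring and is itself unreadable. There is thus no basis for expecting this change to move the value of compound 4 in this assay in either direction beyond the scatter. The most plausible outcome is that compound 4 stays at the same limit as its parent. Compound 4 is accordingly estimated at 100000 nM, with a range from 30000 nM to 500000 nM, which amounts to an expected step of a number no higher from compound 2 to compound 4 (the limit leaves the size open), essentially none.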

Compound 4, half-maximal inhibitory concentration: > 100000 nM
Compound 4: no number, only a limit (the forecaster's own chance of this, stated with the estimate: 85%); the middle value lies on the limit itself.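

Compound 2 and compound 4 each stand only at a limit in this assay, so the change from cyclopropylcarbonyl to ethylcarbamoyl cannot be read as a step: the limit of > 100000 nM in this assay, at which 4 of the 4 values shown sit.

The compounds shown leave open whether either group, or any other change to the shared core, can bring a value within the measurable range of the assay.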